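The source may hold more compounds than are shown below. What is called first, only, known or untested is meant among the compounds shown, and "the series" means these compounds.

Measured in a functional assay on OVCAR-3 cells (Homo sapiens) for antiproliferative activity, read by MTT assay, with a stated time of 24 h; on this read-out higher numbers stand for weaker inhibition and lower numbers for stronger inhibition:
- compound 1 `Cc1ccccc1NNC(=O)c1ccccc1NS(=O)(=O)c1cnc(O)nc1O`: > 20000 nM (a limit)
- compound 2 `O=C(NNc1ccccc1Cl)c1ccccc1NS(=O)(=O)c1cnc(O)nc1O`: 14100 nM

Among the measured compounds shown here, compound 2, at 14100 nM, holds the only actual number in this assay so far. Compound 1 sits at a limit, > 20000 nM. Compound 3 `O=C(NNc1cccc(Cl)c1)c1ccccc1NS(=O)(=O)c1cnc(O)nc1O` differs from compound 2 by 3-chlorophenyl in place of 2-chlorophenyl on an amine nitrogen. For the measured compounds named here, the one measured step, an at least 1.4-fold lower number from compound 1 to compound 2 (0.15 log units; that floor lies within the scatter), exchanges methyl for chloro and does not shift the chloro, so it bears only loosely on this change. No step beyond the scatter is therefore expected. The expected change is a 1.1-fold higher number from compound 2 to compound 3 (0.03 log units; within the scatter). For compound 3 the estimate is 15000 nM, with an expected range of 6000 nM to 30000 nM.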

Compound 3, half-maximal inhibitory concentration: 5520 nM
For compound 3 the middle estimate is 2.7-fold (0.43 log units) above the measured one; measured number below the stated range.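

In this assay, moving the chloro from 2-chlorophenyl to 3-chlorophenyl on the amine nitrogen gives a 2.6-fold lower number from compound 2 to compound 3 (0.41 log units; beyond the scatter) and so shows that this position responds to where the chloro sits, with the same atoms joined differently. Exchanging 2-methylphenyl for 3-chlorophenyl gives an at least 3.6-fold lower number from compound 1 to compound 3 (0.55 log units; beyond the scatter) and so clears the scatter, which the exchange of methyl for chloro alone did not. That step is only a floor, since compound 1 stands at a limit: the limit of > 20000 nM in this assay, at which 1 of the 3 values shown sits. The compounds shown leave open whether a fluoro or a methoxy group in place of the chloro would give the same number, and where an unsubstituted phenyl would stand.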